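A few compounds are considered here, and "the series" means these few. Any claim that something is new, unique, unknown or untested is made for them only; others in the source may bear on it.

Series notes. In an assay on isolated protein for inhibition of receptor-type tyrosine-protein phosphatase C (Homo sapiens), read by spectrophotometry (on this read-out higher numbers stand for weaker inhibition and lower numbers for stronger inhibition), compound 1 `Cc1ccc(O)c(C(O)(C(F)(F)F)C(F)(F)F)c1` gives 207000 nM. Compound 2 `CCN(CC)C(=O)COc1ccc2cc(C(O)(C(F)(F)F)C(F)(F)F)c(O)cc2c1` in this assay returns only a limit, > 20000 nM. Compound 2 thus sits at the limit of > 20000 nM in this assay, at which 1 of the 2 values shown sits, so no number places it against compound 1. Compound 3 `O=C(COc1ccc2cc(C(O)(C(F)(F)F)C(F)(F)F)c(O)cc2c1)Nc1nc2ccccc2s1` differs from compound 2 by (1,3-benzothiazol-2-yl)amino in place of diethylamino on a carbonyl carbon. For the measured compounds named here, with no measured step in hand, this change is expected to shift this assay by an at least 2.0-fold lower number from compound 2 to compound 3 (0.30 log units; that floor lies within the scatter), a move toward stronger inhibition beyond the scatter. Compound 3 is estimated at 10000 nM in this assay, between 2000 nM and 50000 nM.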

Compound 3, half-maximal inhibitory concentration: 10900 nM
Compound 3: middle estimate off by 1.1-fold (0.04 log units), on the low side; the range from low to high includes it.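

With (1,3-benzothiazol-2-yl)amino on a carbonyl carbon, this assay gives a number for compound 3, 10900 nM. Compound 2, with diethylamino at this place, returns only a limit: the limit of > 20000 nM in this assay, at which 1 of the 3 values shown sits.

The change therefore reads as an at least 1.8-fold lower number from compound 2 to compound 3 (0.26 log units; that floor lies within the scatter), a floor and not a measured size, so this position is shown to admit the larger bicyclic group without loss of a measurable value.

Which part of the entering group matters stays open. Anilino or methylamino on the same carbonyl carbon would test the amide hydrogen apart from the fused rings.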